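Trifluoromethyl for fluoro on the aryl substituent of compound 2

The compounds below may be only part of what the source reports. "The series", "measured", "known", "first", "only" and "open" are said of these compounds alone.

Compound 1 `Oc1cc(C(F)(F)F)ccc1-c1nc(-c2ccccc2O)n(-c2ccccc2F)n1` and compound 2 `Oc1cc(C(F)(F)F)ccc1-c1nc(-c2ccccc2O)n(-c2cccc(F)c2)n1` share a core and differ only in the fluorophenyl group on the aromatic nitrogen. In a functional assay on PC-12 cells (Rattus norvegicus) for cytotoxicity, read by MTT assay, with stated times of 2 h and 24 h, tested at 5 uM (a higher number here means a stronger effect of the compound at the concentration tested, a lower number a weaker effect), compound 1 gives 86.6% and compound 2 gives 87.7%. For the measured compounds named here, the single measured step, a number 1.1 percentage points higher from compound 1 to compound 2 (within the scatter), moves the fluoro on that ring and changes little. Compound 2 stands highest of the two numbers, with compound 1 as its nearest neighbour, a gap that lies within the scatter, so no order between them is claimed.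

Compound 3 `Oc1cc(C(F)(F)F)ccc1-c1nc(-c2ccccc2O)n(-c2cccc(C(F)(F)F)c2)n1` is the next member. It differs from compound 2 as follows: trifluoromethyl in place of fluoro on an aromatic carbon. Going by the values given here, no measured step trades fluoro for trifluoromethyl on this ring; the only step in hand, that from compound 1 to compound 2, touches the same ring and stayed within the scatter. On that basis compound 3 is expected to remain near compound 2, with a number 2.7 percentage points lower from compound 2 to compound 3 (within the scatter) expected to be small and of uncertain direction. The estimate for compound 3 in this assay is 85%, expected to fall between 70% and 95%.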

Compound 3, a percentage reported as activity, at one concentration (the size of the read-out at that concentration, not a potency): 92.2%
Beside the measured number, compound 3's estimate is 7.2 percentage points below it; the range from low to high includes it.
By their numbers in this assay, from the lowest: compounds 1, 2 and 3 (each within the scatter of the next).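

In this assay, for the compounds shown here, the earlier compounds only moved a fluoro around this ring, whereas compound 3 puts a group of 4 heavy atoms in place of 1 on the same aromatic carbon, and the exchange of fluoro for trifluoromethyl gives a number 4.5 percentage points higher from compound 2 to compound 3 (within the scatter) in this comparison. The larger group is therefore tolerated at this place, with the read-out staying level with that of the fluoro compound. The wider change, 3-(trifluoromethyl)phenyl in place of 2-fluorophenyl on the aromatic nitrogen, gives a number 5.6 percentage points higher from compound 1 to compound 3 (within the scatter) and so leaves all three compounds without an order, and nothing at hand accounts for how level these numbers are.

The compounds shown carry only fluorine-containing groups on this ring, so it remains open whether an amine, a carboxylic acid or a longer chain such as butyl at the same place would keep the read-out at this level. As far as these compounds go, each number also comes from a single concentration, so how these compounds compare in potency remains open as well.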